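Adding a second chloro to the purine core

This account rests on a few compounds, and the source may have more. Where it says the series, first, only, none or still open, it means among the compounds named here.

Three benzyl-substituted chloropurines have been tested in a functional assay on CCRF-CEM cells (Homo sapiens) for cytotoxicity, read by sulforhodamine B assay, with a stated time of 48 h; a lower number here means that less compound is tolerated, a higher number that more compound is tolerated. Compound 1 `ClCc1ccc(Cn2cnc3c(Cl)ncnc32)cc1` gives only a limit, > 100000 nM, rather than a number. Compound 2 `ClCc1ccccc1Cn1cnc2c(Cl)ncnc21` gives 8120 nM. Compound 3 `ClCc1cccc(Cn2cnc3c(Cl)ncnc32)c1` gives 7620 nM, the lower of the two numbers, but the gap to compound 2 lies within the usual scatter, so the two cannot be ranked against each other. The limit seen for compound 1 is the only other result, (the limit of > 100000 nM in this assay, at which 1 of the 3 values shown sits).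

Compound 4 `ClCc1cccc(Cn2cnc3c(Cl)nc(Cl)nc32)c1` differs from compound 3 in one place: chloro in place of hydrogen on an aromatic carbon. Among the measured compounds shown here, no measured pair shows what such a change does here, so the expectation rests on compound 3 alone. A single added chloro on the core is expected to shift the number only modestly, most likely toward a slightly lower value, though a shift in either direction would not be surprising. On that basis, compound 4 is estimated to give 6000 nM, with a plausible range from 1500 nM to 25000 nM, which corresponds to an expected step of a 1.3-fold lower number from compound 3 to compound 4 (0.10 log units; within the scatter).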

Compound 4, concentration lethal to 50% of the cells: > 100000 nM
Compound 4 ended at the assay's limit; the forecaster's own chance of this, stated with the estimate: 10%; middle value at least 16-fold (1.22 log units) from the limit.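

Among the compounds shown here, until this result, nothing showed what a change at this carbon of the core does. In this assay the chloro in place of hydrogen, on the carbon between two ring nitrogen atoms, gives an at least 13-fold higher number from compound 3 to compound 4 (1.11 log units; beyond the scatter) and so marks this position as highly sensitive, since a single added heavy atom, with no ring and no charge, means that far more compound is tolerated. Compound 4 stands at a limit of the assay rather than at a number, a place it shares with one other compound: the limit of > 100000 nM in this assay, at which 2 of the 4 values shown sit.

From the compounds shown here alone, it remains open whether this step belongs to the chloro itself or would also follow from an amine, a methoxy group or a fluoro on the same carbon. One pair also cannot show whether the same chloro would have a similar result on compound 2, where the chloromethyl group sits elsewhere.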